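The compounds below may be only part of what the source reports. "The series", "measured", "known", "first", "only" and "open" are said of these compounds alone.

In an ADME assay on microsomes from liver (Homo sapiens) for metabolic stability, using NADPH, with a stated time of 40 min, tested at 2 uM (a lower number here means that the compound disappears faster, a higher number that the compound lasts longer), the measured compounds are:
compound 1 (`Cc1cccc2c(-c3ccc4c(O)cccc4n3)c[nH]c12`) gives 0.283 h
compound 2 (`Fc1cc2c(-c3ccc4c(C(F)(F)F)cccc4n3)c[nH]c2c(F)c1F`) gives 1.12 h
compound 3 (`Cc1cccc2c(-c3ccc4ccc(Cl)cc4n3)c[nH]c12`) gives 1.48 h

Compound 1 has the lowest of the three numbers, and both other compounds lie beyond the scatter above it. Compound 4 (`Cc1cccc2c(-c3ccc4c(C(F)(F)F)cccc4n3)c[nH]c12`) differs from compound 1 in one place, with trifluoromethyl in place of hydroxy on an aromatic carbon. Among the measured compounds shown here, no measured pair isolates this change, so its size cannot be read directly from the series. Compound 2 also carries trifluoromethyl and gives 1.12 h on a differently substituted core. Compound 3 has no hydroxy and gives 1.48 h as well. For the measured compounds named here, compound 1 is the only measured compound with hydroxy, though three compounds are too few to establish a pattern. On these values, the expected step of a 3.5-fold higher number from compound 1 to compound 4 (0.55 log units; beyond the scatter) is a rise beyond the scatter. For compound 4 the estimated half-life is 1 h and the expected range runs from 0.45 h to 2.2 h in this estimate.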

Compound 4, half-life: 1.25 h
Compound 4: the middle estimate sits 1.3-fold (0.10 log units) below what was measured, within the range that was stated.
By their numbers in this assay, from the lowest: compound 1; then compounds 2, 4 and 3 (each within the scatter of the next).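

Among the compounds shown here, on the shared core, trifluoromethyl in place of hydroxy on an aromatic carbon gives in this assay the first direct reading of this change, a 4.4-fold higher number from compound 1 to compound 4 (0.65 log units; beyond the scatter), and the step lies beyond the scatter. For the compounds shown here, with everything else in the structure held constant, the longer half-life of compound 4 over compound 1 can be assigned to this one place, which the earlier compounds, differing from compound 1 in more than one place, could not show. Nothing available here explains why the half-life changes with this swap.

A single pair cannot separate the loss of hydroxy from the arrival of trifluoromethyl. Also open, going by these compounds, are how a methoxy group, an amine or a single fluorine at this place would compare, and whether the step carries over to other cores.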